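Chloro to fluoro exchange in a three-compound series

The source may hold more compounds than are shown below. What is called first, only, known or untested is meant among the compounds shown, and "the series" means these compounds.

Measured so far:
compound 1 `NC(=O)c1c(NC(=O)c2ccccc2Cl)sc2c1CCN(C(=S)Nc1cc(C(F)(F)F)cc(C(F)(F)F)c1)C2` gives 15000 nM in a functional assay on MKN-74 cells (Homo sapiens) for antiproliferative activity, with a stated time of 24 h; on this read-out higher numbers stand for weaker inhibition and lower numbers for stronger inhibition
compound 2 `NC(=O)c1c(NC(=O)c2ccccc2Br)sc2c1CCN(C(=S)Nc1ccccc1Cl)C2` gives 12900 nM in this assay
compound 3 `NC(=O)c1c(NC(=O)c2ccccc2F)sc2c1CCN(C(=S)Nc1cc(C(F)(F)F)cc(C(F)(F)F)c1)C2` gives 13300 nM in this assay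

All three values lie within the scatter of one another, so no order among them can be read. Compound 1 and compound 3 differ by fluoro in place of chloro on an aromatic carbon and the step is a 1.1-fold lower number from compound 1 to compound 3 (0.05 log units; within the scatter), that is, no change beyond the noise. The difference between the core of compound 1 and the core of compound 2 is not broken down here.

Compound 4 `NC(=O)c1c(NC(=O)c2ccccc2Br)sc2c1CCN(C(=S)Nc1ccccc1F)C2` is not yet measured. It differs from compound 2 by fluoro in place of chloro on an aromatic carbon. The place description is the same as for the change from compound 1 to compound 3, so this counts as the same change made a second time, two occurrences in all.

On the strength of compound 1 to compound 3 giving a 1.1-fold lower number from compound 1 to compound 3 (0.05 log units; within the scatter), the step from compound 2 to compound 4 in this assay is expected to be a 1.1-fold lower number from compound 2 to compound 4 (0.03 log units; within the scatter), again within the scatter. Compound 4 is therefore estimated at 12000 nM, with a likely range from 6000 nM to 25000 nM.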

Compound 4, half-maximal inhibitory concentration: > 50000 nM
Compound 4 was reported as a limit; the forecaster's own chance of this, stated with the estimate: 10%; middle value at least 4.1-fold (0.61 log units) from the limit.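

Fluoro in place of chloro on an aromatic carbon does not carry over as one fixed step between the two cores in this assay: the same change on two cores in this assay, a 1.1-fold lower number (0.05 log units; within the scatter) from compound 1 to compound 3 and an at least 3.8-fold higher number (0.58 log units; beyond the scatter) from compound 2 to compound 4, at least 4.3-fold (0.64 log units) apart, beyond the scatter of two such steps

Compound 4 gives > 50000 nM, which is a limit and not a number.

The change therefore reads an at least 3.8-fold higher number from compound 2 to compound 4 (0.58 log units; beyond the scatter), so its direction on this core is shown but its full size is not; with only two occurrences, and with the chloro of compound 2 on a (2-chlorophenyl)amino group while that of compound 1 sits elsewhere, the data do not show whether the core or the site of the exchange separates the two results.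

The compounds shown leave open whether the (2-chlorophenyl)amino group of compound 2 is a special case or whether bromo, methyl or methoxy in place of the chloro would also hold the number near that of compound 2. Also open, as far as these compounds go, is whether the same exchange on the (2-chlorophenyl)amino group would behave alike on a core carrying another halogen-bearing benzoyl group.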